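Acetoxy for Phenyl on the Piperidine Ring

A few compounds are considered here, and "the series" means these few. Any claim that something is new, unique, unknown or untested is made for them only; others in the source may bear on it.

Measured compounds:
compound 1 `CC(C(=O)NCc1ccc(C(F)(F)F)nc1NC1CCCCC1)c1ccc(NS(C)(=O)=O)c(F)c1`, 260 nM
compound 2 `CC(C(=O)NCc1ccc(C(F)(F)F)nc1N1CCC(C)(C)CC1)c1ccc(NS(C)(=O)=O)c(F)c1`, 8 nM
compound 3 `CC(C(=O)NCc1ccc(C(F)(F)F)nc1N1CCC(c2ccccc2)CC1)c1ccc(NS(C)(=O)=O)c(F)c1`, 25 nM

In a functional assay on CHO-K1 cells for antagonist activity at transient receptor potential cation channel subfamily V member 1 (Homo sapiens), read by FLIPR (a lower number here means a stronger inhibitor, a higher number a weaker inhibitor), compound 3 stands second of the three numbers: a 3.1-fold higher number from compound 2 to compound 3 (0.49 log units; beyond the scatter), while a 10-fold lower number from compound 1 to compound 3 (1.02 log units; beyond the scatter). Compound 4 `CC(=O)OC1CCN(c2nc(C(F)(F)F)ccc2CNC(=O)C(C)c2ccc(NS(C)(=O)=O)c(F)c2)CC1` differs from compound 3 by acetoxy in place of phenyl on a saturated ring carbon. Going by the values given here, none of the measured steps swaps the group on that saturated ring carbon for an acetoxy; a 33-fold lower number from compound 1 to compound 2 (1.51 log units; beyond the scatter) and a 10-fold lower number from compound 1 to compound 3 (1.02 log units; beyond the scatter) only show that both piperidines outperform cyclohexylamino, and a 3.1-fold higher number from compound 2 to compound 3 (0.49 log units; beyond the scatter) that this ring carbon tolerates two different substituents with a modest gap. Compound 4 is therefore expected to remain close to compound 3, with a step of a 1.6-fold higher number from compound 3 to compound 4 (0.20 log units; within the scatter), the estimate for compound 4 being 40 nM within 10 nM to 160 nM.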

Compound 4, half-maximal inhibitory concentration: 139 nM
Compound 4: middle estimate off by 3.5-fold (0.54 log units), on the low side, and the stated range covers the measured number.
By their numbers in this assay, from the lowest: compound 2; then compound 3; then compounds 4 and 1 (each within the scatter of the next).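

The ring carbon three ring bonds from the ring nitrogen is less forgiving than compound 2 and compound 3 suggested: acetoxy in place of phenyl gives a 5.6-fold higher number from compound 3 to compound 4 (0.75 log units; beyond the scatter) and 4-acetoxypiperidin-1-yl in place of 4,4-dimethylpiperidin-1-yl gives a 17-fold higher number from compound 2 to compound 4 (1.24 log units; beyond the scatter) at this site. The piperidine alone does not carry the gain over cyclohexylamino, since a 1.9-fold lower number from compound 1 to compound 4 (0.27 log units; within the scatter) stays within the scatter. Nothing available explains this drop. Still open, on these data alone, is whether a hydroxyl, a methoxy or an amine on that ring carbon would behave like acetoxy or like phenyl.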